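A few compounds are considered here, and "the series" means these few. Any claim that something is new, unique, unknown or untested is made for them only; others in the source may bear on it.

Compound 1, `COc1cc(C(=O)c2sc(-c3ccc(Cl)cc3)cc2N)cc(OC)c1OC`: 90 nM
Compound 2, `COc1cc(C(=O)c2sc(-c3ccc(C(F)(F)F)cc3)cc2N)cc(OC)c1OC`: 540 nM
Compound 3, `COc1cc(C(=O)c2sc(-c3ccc([N+](=O)[O-])cc3)cc2N)cc(OC)c1OC`: 64 nM

In a functional assay on FM3A cells (Mus musculus) for antiproliferative activity (on this read-out lower numbers stand for stronger inhibition and higher numbers for weaker inhibition), compound 3 gives the lowest of the three numbers, though its gap to compound 1 is within the scatter, a 1.4-fold lower number from compound 1 to compound 3 (0.15 log units; within the scatter), so the two cannot be ranked; only compound 2 stands apart, an 8.4-fold lower number from compound 2 to compound 3 (0.93 log units; beyond the scatter).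

Compound 4, `COc1ccc(-c2cc(N)c(C(=O)c3cc(OC)c(OC)c(OC)c3)s2)cc1`, has not yet been measured in this assay. It differs from compound 3 at one place: methoxy in place of nitro on an aromatic carbon. Of the measured steps, the two exchanges at the same aromatic carbon bear on it. Chloro to trifluoromethyl moved the number modestly, a 6.0-fold higher number from compound 1 to compound 2 (0.78 log units; beyond the scatter), while chloro to nitro left it within the scatter. Replacing nitro by methoxy is a comparable exchange at the same position, so a step of at most modest size is expected in this assay, with no clear direction given by the data. For compound 4 the expected number is 120 nM, with a range of 25 nM to 600 nM, which corresponds to an expected step of a 1.9-fold higher number from compound 3 to compound 4 (0.27 log units; within the scatter).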

Compound 4, half-maximal inhibitory concentration: 31 nM
Compound 4: the middle estimate sits 3.9-fold (0.59 log units) above what was measured, and the stated range covers the measured number.
By their numbers in this assay, from the lowest: compound 4; then compounds 3 and 1 (each within the scatter of the next); then compound 2.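

In this assay, methoxy gives the lowest number of the four groups on this aromatic carbon, and it stands clear of each of the others: (a 2.1-fold lower number from compound 3 to compound 4 (0.31 log units; beyond the scatter)), (a 2.9-fold lower number from compound 1 to compound 4 (0.46 log units; beyond the scatter)) and (a 17-fold lower number from compound 2 to compound 4 (1.24 log units; beyond the scatter)). Nitro and chloro could not be told apart at this position, so 4-methoxyphenyl is the first group to fall clearly below both, and the exchange of trifluoromethyl for methoxy is the largest step seen at this carbon. No measurement is available that accounts for this order of the groups.

The compounds shown leave open whether the low number is particular to methoxy or also holds for ethoxy, a hydroxyl or an amine on the same carbon. They also do not tell whether methoxy would behave alike on another carbon of this ring.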